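A few compounds are considered here, and "the series" means these few. Any claim that something is new, unique, unknown or untested is made for them only; others in the source may bear on it.

In a functional assay on MOLT-4 cells (Homo sapiens) for antiproliferative activity, read by MTT assay, with a stated time of 72 h (on this read-out higher numbers stand for weaker inhibition and lower numbers for stronger inhibition), compound 1 `O=C1NC(=S)S/C1=C\C1=Cc2ccccc2OC1` gives 52000 nM. Compound 2 `O=C(O)CN1C(=O)/C(=C/C2=Cc3ccccc3OC2)SC1=S` carries the change carboxymethyl in place of hydrogen on an amide-type nitrogen in a ring and reaches only the limit of this assay, > 100000 nM. The step of an at least 1.9-fold higher number from compound 1 to compound 2 (0.28 log units; that floor lies within the scatter) thus rests on one value that is a limit, as shown by the limit of > 100000 nM in this assay, at which 1 of the 3 values shown sits, and its true size is not known. Compound 3 `CC1Oc2ccc(Br)cc2C=C1/C=C1\SC(=S)NC1=O` gives 20500 nM in this assay; how its core differs from that of compound 1 is not broken down here. Compound 4 `CC1Oc2ccc(Br)cc2C=C1/C=C1\SC(=S)N(CC(=O)O)C1=O` is not yet measured and differs from compound 3 by the same change, (carboxymethyl in place of hydrogen on an amide-type nitrogen in a ring). Going by the values given here, since the one earlier instance of this change moved the number from a measured value to a limit, compound 4 is expected to give a higher number than compound 3, with a step of about a 2.9-fold higher number from compound 3 to compound 4 (0.47 log units; beyond the scatter), though the floor of the earlier step leaves the size uncertain. The estimate for compound 4 in this assay is 60000 nM, lying between 22000 nM and 160000 nM.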

Compound 4, half-maximal inhibitory concentration: > 50000 nM
Compound 4 ended at the assay's limit; the forecaster's own chance of this, stated with the estimate: 35%; the middle value lies beyond the limit too.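

In this assay compound 4 stands at a limit of the assay, > 50000 nM, which is not a measured number. Carboxymethyl in place of hydrogen on the amide-type nitrogen gives an at least 2.4-fold higher number from compound 3 to compound 4 (0.38 log units; beyond the scatter), so on the core of compound 3 the change raises the number beyond the scatter, whereas on the core of compound 1 the floor of the step stays within it. Both steps point the same way on the two cores shown, but this does not show that the change has the same size on each, or what it would do on any further core: the same change on two cores in this assay, an at least 1.9-fold higher number (0.28 log units; that floor lies within the scatter) from compound 1 to compound 2 and an at least 2.4-fold higher number (0.38 log units; beyond the scatter) from compound 3 to compound 4; the limit leaves it open whether they differ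

The compounds shown leave open whether a methyl group, a longer chain ending in a carboxylic acid or a methyl ester on that nitrogen would also give a higher number. They also leave open which part of the difference between the core of compound 1 and the core of compound 3 matters, as the two differ in more than one place.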